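A few compounds are considered here, and "the series" means these few. Any claim that something is new, unique, unknown or untested is made for them only; others in the source may bear on it.

Three compounds sharing the core of compound 1 have numbers in a functional assay (aorta) for inhibition, with Rattus norvegicus as the target; a lower number here means a stronger inhibitor, a higher number a weaker inhibitor. Compound 1 `C/N=C(/S)[C@]1(c2cccnc2)CCCC[S@@+]1[O-]` has several entries, 700 nM; 400 nM; > 30000 nM (3 entries). The entry carrying a sign is a limit of the assay and not a number. Compound 2 `C/N=C(\S)[C@]1(c2cccc(F)c2)CCCC[S+]1[O-]` gives 7000 nM, and compound 3 `CCC/N=C(\S)[C@]1(c2cccnc2)CCCC[S+]1[O-]` gives 600 nM. Of the two compounds with a single number, compound 3 stands lowest, and its gap to compound 2 lies beyond the scatter.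

Compound 4 `CNC(=O)[C@]1(c2cccnc2)CCCC[S+]1[O-]` has not yet been measured. Starting from compound 3, it puts methylcarbamoyl in place of a group of 6 heavy atoms on a saturated ring carbon, next to the ring sulfur: a group of 4 heavy atoms (2 carbon, 1 nitrogen, 1 oxygen; no ring) in place of a group of 6 heavy atoms (4 carbon, 1 nitrogen, 1 sulfur; no ring), on a saturated ring carbon. Going by the values given here, no measured compound carries methylcarbamoyl, and no measured step isolates this change, so the expectation is a rough one. The group that leaves holds a sulfur, as does the group at that place in compound 1 and compound 2. Compound 2 at 7000 nM shows that a modest change to the series can leave a much higher number in this assay. A higher number, meaning a weaker inhibitor, is therefore expected, by a margin beyond the scatter. The expected move is a 13-fold higher number from compound 3 to compound 4 (1.12 log units; beyond the scatter). For compound 4 the estimated value is 8000 nM, with an expected range of 1500 nM to 30000 nM.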

Compound 4, concentration for 90% inhibition: > 30000 nM
Compound 4 was reported as a limit; the forecaster's own chance of this, stated with the estimate: 35%; middle value at least 3.7-fold (0.57 log units) away from the limit.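

In this assay compound 4 gives > 30000 nM, which is a limit of the assay and not a number. On a saturated ring carbon, next to the ring sulfur, methylcarbamoyl in place of the sulfur-bearing group gives an at least 50-fold higher number from compound 3 to compound 4 (1.69 log units; beyond the scatter), a large step and the only comparison shown that isolates a single place. Every earlier compound carried a sulfur-bearing group here, so this place had not been tested, and the step now shows that the number in this assay depends strongly on the group it holds, even though the two groups match in hydrogen-bond donors, hydrogen-bond acceptors and double bonds outside aromatic rings.

The compounds shown leave open whether the sulfur-to-oxygen exchange or the smaller group size goes with the step, and how a longer chain on the amide nitrogen, an amine or a carboxylic acid at this place would read. The starting level of the series is also less firm than a single number would make it, as compound 1 shows: the several entries of compound 1 in this assay, 700 nM; 400 nM; > 30000 nM (3 entries).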